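The source may report more compounds than this note shows. Statements on the series, on what has been measured and on what is new or still open speak of the compounds shown alone.

Measured so far in an assay on CHO cells for displacement of a labelled ligand from adenosine receptor A1 (Homo sapiens), read by scintillation counting, with a stated time of 1 h; on this read-out lower numbers stand for stronger inhibition and higher numbers for weaker inhibition:
Compound 1 `Cc1cccc(-c2cnc(N)nc2-c2ccccc2)c1` gives 205 nM in this assay.
Compound 2 `CCCC(=O)Nc1ncc(-c2cccc(Cl)c2)c(-c2ccccc2)n1` gives 106 nM in this assay.
Compound 3 `Clc1cccc(-c2cnc(NC3CCCC3)nc2-c2ccccc2)c1` gives 94 nM in this assay.

Compound 3 has the lowest of the three numbers. Compound 2 sits nearest to it, with a gap that lies within the scatter, so the two cannot be ordered; compound 1 stands furthest away, with a higher number, and that gap lies beyond the scatter.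

Compound 4 `OCCCCNc1ncc(-c2cccc(Cl)c2)c(-c2ccccc2)n1` has not yet been measured in this assay. It differs from compound 3 in one place: 4-hydroxybutyl in place of cyclopentyl on a nitrogen on an aromatic ring. Going by the values given here, the only measured step at this same nitrogen is a 1.1-fold lower number from compound 2 to compound 3 (0.05 log units; within the scatter), which exchanged one substituent for another and left the number essentially unchanged. Among the compounds with values here, no measured step exchanges a ring for an open chain carrying a hydroxyl, so the data give no direct precedent for this move.

Given that the one step at this position moved little, a modest step is expected for compound 4, leaning toward a higher number, as a 2.1-fold higher number from compound 3 to compound 4 (0.33 log units; beyond the scatter). For compound 4 in this assay the estimate is 200 nM, with a range from 60 nM to 700 nM.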

Compound 4, inhibition constant: 130 nM
Compound 4: the middle estimate sits 1.5-fold (0.19 log units) above what was measured, and the stated range covers the measured number.
By their numbers in this assay, from the lowest: compounds 3, 2, 4 and 1 (each within the scatter of the next, the first and the last beyond it).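

In this assay the exchange of cyclopentyl for 4-hydroxybutyl on a nitrogen on an aromatic ring gives a 1.4-fold higher number from compound 3 to compound 4 (0.14 log units; within the scatter) and so shows that, on this read-out, a ring of carbon only and an open chain carrying a hydroxyl cannot be told apart at this place, even though 4-hydroxybutyl brings a hydrogen-bond donor and acceptor that cyclopentyl lacks. The comparison with the amide gives a 1.2-fold higher number from compound 2 to compound 4 (0.09 log units; within the scatter) and, taken with the earlier step, places propylcarbonyl, cyclopentyl and 4-hydroxybutyl within the scatter of one another, so this nitrogen has now accepted three quite different substituents with no readable difference among compound 2, compound 3 and compound 4. Nothing shown here offers an explanation for this flat response.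

The compounds shown include no plain butyl group on this nitrogen, so the hydroxyl cannot be separated from the chain that carries it. As far as these compounds go, it also remains open whether the flat response would persist with a longer chain or with an amine or a carboxylic acid at the end of the chain.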